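Removing 3-methylbut-2-en-1-yl from compound 1

The compounds below may be only part of what the source reports. "The series", "measured", "known", "first", "only" and "open" are said of these compounds alone.

Measured in a functional assay on HepG2 cells (Homo sapiens) for inhibition, read by MTT assay, with a stated time of 72 h; on this read-out higher numbers stand for weaker inhibition and lower numbers for stronger inhibition:
- compound 1 `COc1ccccc1/C=C/C(=O)c1c(OC)cc(O)c(CC=C(C)C)c1O`: 14600 nM
- compound 2 `COc1cc(O)c(CC=C(C)C)c(O)c1C(=O)/C=C/c1cccc([N+](=O)[O-])c1`: 16600 nM

Compound 1 has a single measured neighbour, and the two values lie within the scatter of each other: a 1.1-fold higher number from compound 1 to compound 2 (0.06 log units; within the scatter). Compound 3 `COc1ccccc1/C=C/C(=O)c1c(O)cc(O)cc1OC` is the next case, with hydrogen in place of 3-methylbut-2-en-1-yl on an aromatic carbon. Within the data shown here, the only measured step, with 3-nitrophenyl in place of 2-methoxyphenyl, concerns another part of the molecule. Both measured compounds carry 3-methylbut-2-en-1-yl, so the data contain no direct measure of its loss. A modest shift towards weaker inhibition is nevertheless expected, though this is a judgement with wide uncertainty. The estimated size is a 2.4-fold higher number from compound 1 to compound 3 (0.38 log units; beyond the scatter). For compound 3 the expected value in this assay is 35000 nM, with an estimated range of 15000 nM to 85000 nM.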

Compound 3, half-maximal inhibitory concentration: 15300 nM
Estimate against measurement, compound 3: 2.3-fold (0.36 log units) above; the measured number falls inside the stated range.
By their numbers in this assay, from the lowest: compounds 1, 3 and 2 (each within the scatter of the next).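

Among these compounds, removing 3-methylbut-2-en-1-yl from the aromatic carbon ortho to two hydroxy groups gives the first direct reading at this position: in this assay the change is a 1.0-fold higher number from compound 1 to compound 3 (0.02 log units; within the scatter). With 2-methoxyphenyl in the molecule, hydrogen therefore stands in for the whole chain with no change beyond the scatter, so in this assay the presence of 3-methylbut-2-en-1-yl at this carbon is not required for the inhibition read here. No supporting data are available to explain this result.

On these data alone, it remains open whether an amine, a carboxylic acid or a longer chain at this aromatic carbon would also leave the number within the scatter. As far as these compounds go, it is also open whether hydrogen in place of 3-methylbut-2-en-1-yl would behave the same way alongside 3-nitrophenyl.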